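Working notes: isopropyl to methyl on an aromatic nitrogen

The compounds below may be only part of what the source reports. "The series", "measured", "known", "first", "only" and "open" are said of these compounds alone.

Compound 1 `Cc1cc(=O)oc2nn(C)c(C)c12` and compound 2 `Cc1cc(=O)oc2nn(C(C)C)c(C)c12` share one core, while compound 3 `Cc1cc(=O)oc2c1c(C)nn2C(C)C` and compound 4 `Cc1cc(=O)oc2c1c(C)nn2C` share another. The difference between the two cores is not broken down here. In a functional assay on the whole organism with Mus musculus as the target, in the writhing test (a lower number here means that less compound is needed, a higher number that more compound is needed for the effect), compound 1 gives 6.09 mg/kg, and compound 2 gives 35.3 mg/kg. The change from compound 2 to compound 1 is methyl in place of isopropyl on an aromatic nitrogen and it gave a 5.8-fold lower number from compound 2 to compound 1 (0.76 log units; beyond the scatter). For compound 3 the result in this assay is only a limit, > 100 mg/kg, and the limit of > 100 mg/kg in this assay, at which 1 of the 3 values shown sits, shows where that result stands. Compound 4 differs from compound 3 by methyl in place of isopropyl on an aromatic nitrogen. For the measured compounds named here, this is the same kind of change as the one leading to compound 1, not the same change: in compound 1 the methyl on the aromatic nitrogen sits next to the ring atom that bears a methyl group, whereas in compound 4 it sits two ring bonds from the ring atom that bears a methyl group. For compound 4 a step of roughly the earlier size, an at least 2.5-fold lower number from compound 3 to compound 4 (0.39 log units; beyond the scatter), is expected, resting on a 5.8-fold lower number from compound 2 to compound 1 (0.76 log units; beyond the scatter), though the starting point is only a limit. Compound 4 is therefore estimated at 40 mg/kg, with a range from 10 mg/kg to 200 mg/kg.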

Compound 4, dose for half-maximal effect: 11.6 mg/kg
Compound 4: middle estimate off by 3.4-fold (0.54 log units), on the high side; low and high end bracket the measured number.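

In this assay, methyl in place of isopropyl on an aromatic nitrogen gives an at least 8.6-fold lower number from compound 3 to compound 4 (0.93 log units; beyond the scatter), so the direction seen on the core of compound 1 carries over to the core of compound 4. For compound 3 the result, > 100 mg/kg, is a limit of the assay and not a number, which leaves the full size of this step unknown. The data therefore show a shared direction but not a shared size, and whether the change is worth the same on both cores cannot be said: the same change on two cores in this assay, a 5.8-fold lower number (0.76 log units; beyond the scatter) from compound 2 to compound 1 and an at least 8.6-fold lower number (0.93 log units; beyond the scatter) from compound 3 to compound 4; the limit leaves it open whether they differ

Only methyl and isopropyl appear on the aromatic nitrogen in the compounds shown, so it remains open how an ethyl group, a longer chain or a chain ending in an amine would read in this assay. Going by these compounds, it also remains open whether the direction holds on any core beyond these two, as it rests on just two pairs of compounds.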